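Phenyl to thiophene on the oxadiazole-bearing acid series

The source may hold more compounds than are shown below. What is called first, only, known or untested is meant among the compounds shown, and "the series" means these compounds.

Three acids have numbers in a functional assay on CHO cells for agonist activity at Free fatty acid receptor 1 (Homo sapiens), read by FLIPR and calcium flux, in the presence of a further agent that is not named here; a higher number here means that more compound is needed for the effect, a lower number that less compound is needed. Compound 1 `O=C(O)CCc1ccc(OCc2nc(-c3ccccc3)no2)cc1` gives 1130 nM. Compound 2 `CC(Oc1ccc(CCC(=O)O)cc1)c1nc(-c2ccccc2)no1` gives 2390 nM, and compound 3 `O=C(O)CCc1ccc(OCc2coc(-c3ccccc3)n2)cc1` gives 700 nM. Among the measured compounds shown here, compound 2 stands at the highest of the three numbers: nearest is compound 1, and the step of a 2.1-fold higher number from compound 1 to compound 2 (0.33 log units; beyond the scatter) is modest; furthest is compound 3, which needs less compound than compound 2, though the two differ in the core and no single step connects them.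

Compound 4 `CC(Oc1ccc(CCC(=O)O)cc1)c1nc(-c2cccs2)no1` is not yet measured. Relative to compound 2 it carries thiophen-2-yl in place of phenyl on an aromatic carbon. For the measured compounds named here, the one measured step, a 2.1-fold higher number from compound 1 to compound 2 (0.33 log units; beyond the scatter), concerns the methyl on the chain carbon and not the aryl group, so no measured step bears on this exchange. With nothing to point either way, the expected step of a 1.1-fold lower number from compound 2 to compound 4 (0.04 log units; within the scatter) in this assay is none beyond the scatter. Compound 4 is therefore estimated at 2200 nM, with a range from 800 nM to 6000 nM.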

Compound 4, half-maximal effective concentration: 4000 nM
The estimate for compound 4 lay 1.8-fold (0.26 log units) below the measured number; low and high end bracket the measured number.
By their numbers in this assay, from the lowest: compounds 3 and 1 (each within the scatter of the next); then compounds 2 and 4 (each within the scatter of the next).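

At the aromatic carbon between two ring nitrogen atoms, the step of a 1.7-fold higher number from compound 2 to compound 4 (0.22 log units; within the scatter) in this assay stays inside the usual scatter, so thiophen-2-yl and phenyl cannot be told apart at this position. Among the compounds shown here, the only earlier step of a 2.1-fold higher number from compound 1 to compound 2 (0.33 log units; beyond the scatter) lay on the chain carbon, which makes this the sole reading at the aryl position, and it rests on one pair that carries the chain methyl. No measurement on hand offers an explanation for this result.

Going by these compounds, whether the same exchange would read alike on the core of compound 1 or the core of compound 3 remains open. Also open, on these data alone, is how furan-2-yl, pyridin-2-yl or a phenyl carrying a fluorine would compare at this position.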